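Phosphate diester chain length on the shared core

This account rests on a few compounds, and the source may have more. Where it says the series, first, only, none or still open, it means among the compounds named here.

Compound 3 (`COP(=O)(OC)OC[C@H]1O[C@@H](n2cnc3c(NC4CCCC4)nc(Cl)nc32)[C@H](O)[C@@H]1O`) is the dimethyl phosphate ester in a short set built on one shared core. In an in vitro functional assay on HEK-293T cells for agonist activity at adenosine receptor A1 (Homo sapiens), read by a luciferase reporter and cAMP accumulation, with a stated time of 10 min (a higher number here means that more compound is needed for the effect, a lower number that less compound is needed), compound 3 gives 1400 nM, the second highest of the three numbers measured. Going by the values given here, the free phosphate, compound 1 (`O=P(O)(O)OC[C@H]1O[C@@H](n2cnc3c(NC4CCCC4)nc(Cl)nc32)[C@H](O)[C@@H]1O`), gives 72 nM in this assay, and the step of a 19-fold higher number from compound 1 to compound 3 (1.29 log units; beyond the scatter) is the only single-change step recorded so far. The bis-phenethyl ester, compound 2 (`O=P(OCCc1ccccc1)(OCCc1ccccc1)OC[C@H]1O[C@@H](n2cnc3c(NC4CCCC4)nc(Cl)nc32)[C@H](O)[C@@H]1O`), gives 6100 nM in this assay; compound 2 and compound 3 are not a single-change pair, so their two values are simply set side by side: compound 2 carries the higher number, beyond the scatter of compound 3.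

Compound 4 (`CCOP(=O)(OCC)OC[C@H]1O[C@@H](n2cnc3c(NC4CCCC4)nc(Cl)nc32)[C@H](O)[C@@H]1O`) is the diethyl ester. The change is a group of 8 heavy atoms (4 carbon, 3 oxygen, 1 phosphorus; no ring) in place of a group of 6 heavy atoms (2 carbon, 3 oxygen, 1 phosphorus; no ring), on an oxygen on a saturated carbon. Among the compounds with values here, no measured step covers this exact change; the recorded step a 19-fold higher number from compound 1 to compound 3 (1.29 log units; beyond the scatter) concerns the free acid against the dimethyl ester and does not transfer directly, while the values of compound 3 and compound 2 show that the larger diester carries the higher number. A modest upward step in this assay is therefore expected, a 1.8-fold higher number from compound 3 to compound 4 (0.25 log units; within the scatter), though it may still fall within the scatter. Compound 4 is expected to give 2500 nM in this assay, with a range from 1000 nM to 6500 nM.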

Compound 4, half-maximal effective concentration: > 10000 nM
Compound 4 was reported as a limit; the forecaster's own chance of this, stated with the estimate: 5%; middle value at least 4.0-fold (0.60 log units) away from the limit.
By their numbers in this assay, from the lowest: compound 1; then compound 3; then compound 2. At a limit, above all of these: compound 4.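

For compound 4 the read-out in this assay is a limit and not a number: the limit of > 10000 nM in this assay, at which 1 of the 4 values shown sits.

Replacing the dimethyl phosphate group with the diethyl phosphate group, on an oxygen on a saturated carbon, gives an at least 7.1-fold higher number from compound 3 to compound 4 (0.85 log units; beyond the scatter), so a change of only the ester chains within the diester set is enough to move the read-out beyond the scatter, and the distance from the free phosphate grows to an at least 130-fold higher number from compound 1 to compound 4 (2.14 log units; beyond the scatter). Ester size alone does not order the set, however: compound 2, with the larger bis-phenethyl ester, gives 6100 nM, a measured number, and so goes against any steady rise with size of the ester group.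

On these data alone, how far the true value of compound 4 lies past the limit stays unknown, so both new steps give only a minimum size. Also open, as far as these compounds go, is how a monomethyl phosphate with one free acid group, a dipropyl ester with a longer chain, or a phosphoramidate carrying an amine in place of one ester oxygen would read on the shared core.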